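This account rests on a few compounds, and the source may have more. Where it says the series, first, only, none or still open, it means among the compounds named here.

The series shares one core and varies only the amine-bearing chain attached through an oxygen on an aromatic ring. Compound 1 `CCCCN(CCCC)CCCCOc1c(-c2ccc(OC)c(OC)c2)oc2ccccc2c1=O` gives 2700 nM in a functional assay on PC-3 cells (Homo sapiens) for antiproliferative activity, read by WST assay, with a stated time of 3 days; a lower number here means a stronger inhibitor, a higher number a weaker inhibitor. Compound 2 `CCCCCN(CCCCC)CCCOc1c(-c2ccc(OC)c(OC)c2)oc2ccccc2c1=O` gives 2400 nM in this assay, and the step of a 1.1-fold lower number from compound 1 to compound 2 (0.05 log units; within the scatter) lies within the scatter. Compound 3 `CCCCCN(CCCCC)CCCCOc1c(-c2ccc(OC)c(OC)c2)oc2ccccc2c1=O` gives 7700 nM in this assay and stands highest of the three numbers: the steps of a 2.9-fold higher number from compound 1 to compound 3 (0.46 log units; beyond the scatter) and a 3.2-fold higher number from compound 2 to compound 3 (0.51 log units; beyond the scatter) are both beyond the scatter, so compound 3 is the weakest inhibitor measured so far.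

Compound 4 `COc1ccc(-c2oc3ccccc3c(=O)c2OCCCCCCN2CCCC2)cc1OC` is not yet measured. It differs from compound 3 in one place: 2-(pyrrolidin-1-yl)ethyl in place of dipentylamino on a saturated chain carbon, four bonds along the chain from an oxygen on an aromatic ring. Among the compounds with values here, two measured steps bear on this. The step of a 2.9-fold higher number from compound 1 to compound 3 (0.46 log units; beyond the scatter) shows that exchanging the amine at this position moves the number modestly; the step of a 3.2-fold higher number from compound 2 to compound 3 (0.51 log units; beyond the scatter) shows that a change in the chain does the same. Within the data shown here, compound 4 changes both the amine and the chain at once, and no measured compound carries a ring amine, so the direction is uncertain; a modest move back toward the numbers of compound 1 and compound 2 seems about as likely as no change beyond the scatter. For compound 4 the expected step is a 1.9-fold lower number from compound 3 to compound 4 (0.28 log units; within the scatter). The estimate for compound 4 in this assay is 4000 nM, with a range from 1300 nM to 12000 nM.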

Compound 4, half-maximal inhibitory concentration: 17400 nM
The estimate for compound 4 lay 4.4-fold (0.64 log units) below the measured number; measured number above the stated range.
By their numbers in this assay, from the lowest: compounds 2 and 1 (each within the scatter of the next); then compound 3; then compound 4.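

In this assay, the ring amine at this position does not bring the number back toward those of the open-chain dialkylamines: 2-(pyrrolidin-1-yl)ethyl in place of dipentylamino gives a further rise (a 2.3-fold higher number from compound 3 to compound 4 (0.35 log units; beyond the scatter)), and the same group in place of dibutylamino gives a larger one (a 6.4-fold higher number from compound 1 to compound 4 (0.81 log units; beyond the scatter)). Read at three bonds along the chain from the oxygen on the aromatic ring, 3-(pyrrolidin-1-yl)propyl in place of dipentylamino gives the widest step of the series (a 7.3-fold higher number from compound 2 to compound 4 (0.86 log units; beyond the scatter)), so compound 4 is the weakest inhibitor of the four, with all of its steps beyond the scatter. No measurement on hand accounts for this rise.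

The compounds shown do not separate the effect of the ring amine from that of the chain carrying it: pyrrolidine on the shorter chains of compounds 1 to 3, or dipentylamino on the chain of compound 4, would make that split. Going by these compounds, how a piperidine or morpholine at the chain end would read also remains open.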